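A Cyclobutyl Ether in Place of a Trifluoromethyl Ether

The compounds below may be only part of what the source reports. "The series", "measured", "known", "first", "only" and "open" are said of these compounds alone.

Three compounds have been examined in a functional assay on HEK293 cells for agonist activity at Free fatty acid receptor 1 (Homo sapiens), read by HTRF and inositol phosphate accumulation, with a stated time of 60 min; a lower number here means that less compound is needed, a higher number that more compound is needed for the effect. Compound 1 `COc1cc(O[C@H]2C[C@H](OC)C2)nc(-c2ccc3c(c2)CC[C@H](CCC(=O)O)O3)c1F` is reported only as a limit, > 10000 nM. Compound 2 `COc1cc(Oc2ncc(C)s2)cc(-c2ccc3c(c2)CC[C@H](CCC(=O)O)O3)c1F` likewise reaches only the limit of > 10000 nM. Compound 3 `COc1cc(OC(F)(F)F)cc(-c2ccc3c(c2)CC[C@H](CCc2nnn[nH]2)O3)c1F` also gives only a limit, > 10000 nM, so its standing cannot be placed more closely than the limit of > 10000 nM in this assay, at which 3 of the 3 values shown sit. Compound 4 `COc1cc(O[C@H]2C[C@H](OC)C2)cc(-c2ccc3c(c2)CC[C@H](CCc2nnn[nH]2)O3)c1F` has not yet been measured. It differs from compound 3 in one place: 3-methoxycyclobutyl in place of trifluoromethyl on an oxygen on an aromatic ring. Compound 1 already carries the 3-methoxycyclobutyl group on an oxygen on an aromatic ring and still sits at its limit, > 10000 nM. For the measured compounds named here, no measured step calibrates this change, so no movement beyond the scatter is expected in this assay. Compound 4 is therefore expected to remain near 15000 nM, within 3000 nM to 60000 nM. That amounts to an expected step that the limit leaves unreadable from compound 3 to compound 4.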

Compound 4, half-maximal effective concentration: > 10000 nM
Compound 4: no number, only a limit; the forecaster's own chance of this, stated with the estimate: 80%; the middle value lies beyond the limit too.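

For the compounds shown here, compound 3 and compound 4 are each reported only as a limit, so no step between them can be read. The compounds shown leave open how any of them ranks against another: the limit of > 10000 nM in this assay, at which 4 of the 4 values shown sit.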